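Shortening the Chain from Hexyl to Methyl

The source may report more compounds than this note shows. Statements on the series, on what has been measured and on what is new or still open speak of the compounds shown alone.

Compound 1 `CCCCCCCCCCn1c(=O)n(C2OC(CO)[C@@H](O)[C@H]2O)c2nc(N)nc(O)c21` and compound 2 `CCCCCCn1c(=O)n(C2OC(CO)[C@@H](O)[C@H]2O)c2nc(N)nc(O)c21` share one core and differ only in the length of the chain that sits on an aromatic nitrogen. In a functional assay on the whole organism with Mus musculus as the target (a lower number here means a smaller maximal response, a higher number a larger maximal response), compound 1 gives 0%, and compound 2 gives 11%. Compound 2 therefore stands highest of the two numbers measured in this assay; its nearest neighbour is compound 1, whose number is lower by more than the scatter. For the measured compounds named here, the step of a number 11 percentage points higher from compound 1 to compound 2 (beyond the scatter) is the only measured step, and it shows that cutting a butyl piece off the chain raised the maximal response modestly.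

Compound 3 `Cn1c(=O)n(C2OC(CO)[C@@H](O)[C@H]2O)c2nc(N)nc(O)c21` takes the same direction further: hydrogen in place of pentyl on a saturated chain carbon bound to an aromatic nitrogen. Going by the values given here, the one step that bears on this, a number 11 percentage points higher from compound 1 to compound 2 (beyond the scatter), gained a modest amount when the chain was cut back. Cutting away a pentyl piece is expected to move this assay the same way by a step of similar size, a number 11 percentage points higher from compound 2 to compound 3 (beyond the scatter), although a single measured step is thin ground for the expectation. Compound 3 is therefore estimated at 22%, within a range from 5% to 45%.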

Compound 3, largest response reached (reported as maximal response), in percent of the reference or control that the assay uses: 100%
Compound 3: middle estimate off by 78 percentage points, on the low side; the measured number lies above the stated range.
By their numbers in this assay, from the lowest: compound 1; then compound 2; then compound 3.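

In this assay, for the compounds shown here, the chain on this aromatic nitrogen matters far more than the earlier compounds suggested: replacing hexyl with methyl gives a number 89 percentage points higher from compound 2 to compound 3 (beyond the scatter) and dwarfs the earlier change, a number 11 percentage points higher from compound 1 to compound 2 (beyond the scatter) for comparison. Taken end to end, the series gives a number 100 percentage points higher from compound 1 to compound 3 (beyond the scatter) in total, and most of that rise comes with the last shortening, so the response does not climb in even steps as the chain gets shorter. Of the three compounds, only compound 3, with methyl on the aromatic nitrogen, shows a large maximal response, while the two longer chains stay low.

No accompanying measurement accounts for this jump. Still open, from the compounds shown here alone, is where the response rises between hexyl and methyl, which an ethyl, propyl or butyl chain could help locate, and whether hydrogen in place of methyl, or a short chain ending in an amine or a carboxylic acid, would keep the response seen with compound 3.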